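The compounds below may be only part of what the source reports. "The series", "measured", "known", "first", "only" and "open" are said of these compounds alone.

The series shares a single core, with the group on the carbon bearing the double bond to nitrogen as the only point of variation. Compound 1, `CCCCC/C=N/NC(=O)c1ccc(O[C@@H]2O[C@H](CO)[C@@H](O)[C@H](O)[C@H]2O)cc1`, carries a pentyl there, and in a functional assay on MDA-MB-231 cells (Homo sapiens) for inhibition, read by MTT assay, with a stated time of 24 h, tested at 100 uM (on this read-out higher numbers stand for more inhibition at the one concentration tested (going by the name of the read-out) and lower numbers for less inhibition), compound 1 gives 11%. Compound 2, `O=C(N/N=C/c1ccc(F)cc1)c1ccc(O[C@@H]2O[C@H](CO)[C@@H](O)[C@H](O)[C@H]2O)cc1`, carries a 4-fluorophenyl instead, and in this assay compound 2 gives 9.91%. Among the compounds with values here, the one measured step, a number 1.1 percentage points lower from compound 1 to compound 2 (within the scatter), shows that exchanging pentyl for 4-fluorophenyl leaves the read-out essentially unchanged. Compound 2 thus stands at the lower of the two numbers, though its gap to compound 1 is within the scatter, so no order between them can be claimed.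

Compound 3, `CC(C)/C=N/NC(=O)c1ccc(O[C@@H]2O[C@H](CO)[C@@H](O)[C@H](O)[C@H]2O)cc1`, is the next step: isopropyl in place of 4-fluorophenyl on a carbon with a double bond to nitrogen. The only comparison that bears on this is the pentyl-to-4-fluorophenyl step of a number 1.1 percentage points lower from compound 1 to compound 2 (within the scatter), which was within the scatter; it suggests that changes at this position, at least among these three groups, move the read-out little. Compound 3 is therefore expected to give 10.5% in this assay, within 2% to 20%, the expected step being a number 0.6 percentage points higher from compound 2 to compound 3 (within the scatter).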

Compound 3, a percentage reported as inhibition, at one concentration (the size of the read-out at that concentration, not a potency): 1.7%
Compound 3: the middle estimate sits 8.8 percentage points above what was measured; measured number below the stated range.
By their numbers in this assay, from the lowest: compounds 3, 2 and 1 (each within the scatter of the next).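

With isopropyl on the carbon with a double bond to nitrogen, the new steps in this assay are a number 8.2 percentage points lower from compound 2 to compound 3 (within the scatter) and a number 9.3 percentage points lower from compound 1 to compound 3 (within the scatter), so the three compounds still cannot be put in any firm order. The earlier step exchanged pentyl for 4-fluorophenyl, whereas these steps also compare a short branched group with each of them, and even the exchange of 4-fluorophenyl for isopropyl, which removes the aromatic ring and the fluorine, stays within the scatter, as does the exchange of pentyl for isopropyl. Nothing at hand accounts for the size of these steps or shows what the groups do at this position.

As far as these compounds go, whether an amine, a carboxylic acid or a chain longer than pentyl on this carbon would give a number clear of the scatter from these three compounds remains open. With only one concentration shown, the compounds also leave open whether they would separate at other concentrations, and how their potencies compare.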